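Fluorine on the Fused Ring of a Hydroxamic Acid Inhibitor

The source may hold more compounds than are shown below. What is called first, only, known or untested is meant among the compounds shown, and "the series" means these compounds.

Compound 1, `O=C(NO)c1ccc(Cn2[se]c3ccccc3c2=O)cc1`, is one of two compounds tested in an assay on isolated protein for inhibition of protein deacetylase HDAC6 (Homo sapiens), read by fluorescence, with stated times of 15 min and 30 min; a higher number here means a weaker inhibitor, a lower number a stronger inhibitor; compound 1 gives 37 nM, the lower of the two numbers. Compound 2, `CC(c1ccc(C(=O)NO)cc1)n1[se]c2ccccc2c1=O`, gives 863 nM in this assay. For the measured compounds named here, the only measured change, a 23-fold higher number from compound 1 to compound 2 (1.37 log units; beyond the scatter), puts a methyl on the saturated chain carbon bound to an aromatic carbon and an aromatic nitrogen, a place different from the one altered here. Compound 3, `O=C(NO)c1ccc(Cn2[se]c3ccc(F)cc3c2=O)cc1`, differs from compound 1 by fluoro in place of hydrogen on an aromatic carbon. Going by the values given here, no measured step touches that fused ring, so the one known step gives no direct guide, while the hydroxamic acid, the shared core and the linking carbon stay as in compound 1. The expected step is therefore a 1.1-fold higher number from compound 1 to compound 3 (0.03 log units; within the scatter), not beyond the scatter of repeated runs. Compound 3 is estimated at 40 nM, with a likely range from 15 nM to 110 nM.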

Compound 3, half-maximal inhibitory concentration: 178 nM
Estimate against measurement, compound 3: 4.5-fold (0.65 log units) below, and the stated range ends below it.
By their numbers in this assay, from the lowest: compound 1; then compound 3; then compound 2.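

The fused ring is not a neutral place to make a change: in this assay, fluoro in place of hydrogen on this aromatic carbon gives a step beyond the scatter (a 4.8-fold higher number from compound 1 to compound 3 (0.68 log units; beyond the scatter)), and compound 3 is the weaker inhibitor of the pair. For the compounds shown here, until now, the only measured change was the methyl on the linking carbon (a 23-fold higher number from compound 1 to compound 2 (1.37 log units; beyond the scatter)), so this is the first sign that the fused ring also affects the number, even when only one fluorine atom enters. Nothing shown gives a reason for this step.

Going by these compounds, whether chloro, methoxy or an amine on the same aromatic carbon would also raise the number remains open. A single step on this ring cannot show a trend, nor can it show whether fluoro elsewhere on the fused ring would act the same way.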